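From 2-fluorophenyl to 3-methylphenyl on a carbonyl carbon

This account rests on a few compounds, and the source may have more. Where it says the series, first, only, none or still open, it means among the compounds named here.

Of the compounds shown here, three sharing one core have been measured in a functional assay on MCF7 cells (Homo sapiens) for antiproliferative activity, read by MTT assay; on this read-out lower numbers stand for stronger inhibition and higher numbers for weaker inhibition. There, compound 1 `COc1cc2c(Oc3ccc(NC(=O)Nc4ccc(OC(F)(F)F)cc4)cc3)ccnc2cc1OCCCCCCC(=O)NO` gives 3200 nM, compound 2 `COc1cc2c(Oc3ccc(NC(=O)Nc4ccccc4F)cc3)ccnc2cc1OCCCCCCC(=O)NO` gives 660 nM, and compound 3 `COc1cc2c(Oc3ccc(NC(=O)NNC(=O)c4ccccc4F)cc3)ccnc2cc1OCCCCCCC(=O)NO` gives 3600 nM. The numbers show a 1.1-fold higher number from compound 1 to compound 3 (0.05 log units; within the scatter), and also a 5.5-fold higher number from compound 2 to compound 3 (0.74 log units; beyond the scatter). Compound 3 therefore sits at the high end of this small set, level with compound 1 and apart from compound 2.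

Compound 4 `COc1cc2c(Oc3ccc(NC(=O)NNC(=O)c4cccc(C)c4)cc3)ccnc2cc1OCCCCCCC(=O)NO` alters only the aromatic group of compound 3: 3-methylphenyl in place of 2-fluorophenyl on a carbonyl carbon. Among the measured compounds shown here, no measured pair changes the group on this carbonyl carbon, so direct evidence is lacking. The closest guide is a 4.8-fold lower number from compound 1 to compound 2 (0.69 log units; beyond the scatter), a modest step in which one substituted phenyl replaced another, though on an amide-type nitrogen and not on a carbonyl carbon. The steps that end at compound 3 involve a different exchange and say little about this one. A step in this assay no larger than that modest one is expected, most likely none beyond the scatter, with no firm direction. The estimated step is a 1.2-fold lower number from compound 3 to compound 4 (0.08 log units; within the scatter). For compound 4 the expected value is 3000 nM, with an estimated range of 1200 nM to 7500 nM.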

Compound 4, half-maximal inhibitory concentration: 5830 nM
For compound 4 the middle estimate is 1.9-fold (0.29 log units) below the measured one; the measured number falls inside the stated range.
By their numbers in this assay, from the lowest: compound 2; then compounds 1, 3 and 4 (each within the scatter of the next).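

In this assay, among the compounds shown here, this is the first exchange seen on this carbonyl carbon, and 3-methylphenyl in place of 2-fluorophenyl gives a 1.6-fold higher number from compound 3 to compound 4 (0.21 log units; within the scatter), so the read-out at this position tolerates this change of aromatic group without a step beyond the scatter. The comparison with the other compounds stays as it was for compound 3: ((3-methylphenyl)carbonyl)amino on the amide-type nitrogen gives an 8.8-fold higher number from compound 2 to compound 4 (0.95 log units; beyond the scatter), which keeps the clear gap to compound 2, and a 1.8-fold higher number from compound 1 to compound 4 (0.26 log units; within the scatter), which stays level with compound 1, so the larger difference in this set lies with the group on the amide-type nitrogen and not with the group on the carbonyl carbon. No measurement available here offers an explanation for these numbers.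

The exchange swaps the 2-fluorophenyl group for the 3-methylphenyl group in one move, so the compounds shown cannot separate the effect of fluorine versus methyl from that of where each sits; 3-fluorophenyl or 2-methylphenyl would be needed for that. On these data alone, whether a ring bearing an amine or a carboxylic acid on this carbonyl carbon would also stay level also remains open.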